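The compounds below may be only part of what the source reports. "The series", "measured", "known", "first", "only" and "open" are said of these compounds alone.

Compound 1 `N#CCCCc1c[nH]c2ccc(F)cc12`: 72 nM
Compound 2 `NCCCCc1c[nH]c2c(F)cccc12`: 21 nM
Compound 3 `NC(=O)CCc1c[nH]c2c(F)cccc12`: 64 nM

In an assay on isolated protein for inhibition of Myeloperoxidase (Homo sapiens), read by ELISA, with a stated time of 5 min (a lower number here means a stronger inhibitor, a higher number a weaker inhibitor), compound 1 has the highest of the three numbers; its nearest neighbour is compound 3, whose value sits within the scatter of it, while compound 2 lies furthest from it, beyond the scatter. Compound 4 `NC(=O)CCc1c[nH]c2ccc(F)cc12` has not yet been measured. Its difference from compound 1: carbamoyl in place of cyanomethyl on a saturated chain carbon, two bonds along the chain from an aromatic carbon. Within the data shown here, no measured step covers this exact change; the only related step, a 3.0-fold higher number from compound 2 to compound 3 (0.48 log units; beyond the scatter), involves a different departing group and so bears on it only loosely. Compound 3 carries the entering group on a differently fluorinated core and gives 64 nM, close to compound 1. Compound 4 is therefore expected to show no step beyond the scatter, a 1.1-fold lower number from compound 1 to compound 4 (0.04 log units; within the scatter), and its value is estimated at 65 nM, within 25 nM to 170 nM.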

Compound 4, half-maximal inhibitory concentration: 34 nM
Compound 4: the middle estimate sits 1.9-fold (0.28 log units) above what was measured, and the stated range covers the measured number.
By their numbers in this assay, from the lowest: compounds 2, 4, 3 and 1 (each within the scatter of the next, the first and the last beyond it).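

In this assay there is a 2.1-fold lower number from compound 1 to compound 4 (0.33 log units; beyond the scatter) at this saturated chain carbon, so carbamoyl in place of cyanomethyl gives a step beyond the scatter on the core of compound 1. The earlier step with carbamoyl entering, a 3.0-fold higher number from compound 2 to compound 3 (0.48 log units; beyond the scatter), ran the other way, with 2-aminoethyl leaving, so the direction of the change depends on the departing group in these two pairs. Nothing available accounts for this difference.

Open, as far as these compounds go, is whether a carboxylic acid at this place would match carbamoyl, and whether 2-aminoethyl would give a lower number than carbamoyl on the core of compound 1.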